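This account rests on a few compounds, and the source may have more. Where it says the series, first, only, none or still open, it means among the compounds named here.

Measured so far:
Compound 1 `c1coc(-c2ccccc2NCC2=NCCN2)c1` in a functional assay for activation of Alpha-1D adrenergic receptor (Homo sapiens) (on this read-out higher numbers stand for an effect only at larger amounts of compound and lower numbers for an effect already at smaller amounts), gives 16.2 nM.
Compound 2 `Cc1nc(-c2ccccc2NCC2=NCCN2)co1` gives only a limit in this assay, < 5020 nM.

Compound 1 holds the only number shown in this assay; the other value is a limit. Among the measured compounds shown here, the single measured step at this position, a step that the limit leaves unreadable from compound 1 to compound 2, stays unreadable because of the limit of < 5020 nM in this assay, at which 1 of the 2 values shown sits.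

Compound 3 `CO/N=C(\C)c1ccccc1NCC1=NCCN1` is not yet measured. Its change from compound 1: a group of 5 heavy atoms (3 carbon, 1 nitrogen, 1 oxygen; no ring) in place of a group of 5 heavy atoms (4 carbon, 1 oxygen; one five-membered aromatic ring with 1 hetero atom), on an aromatic carbon

For the measured compounds named here, no measured step covers this exchange; the only step leaving compound 1 gives no size, so nothing here fixes the direction. Going by the values given here, the estimate therefore rests on compound 1 alone and is set wide, leaning toward a weaker effect, since the one recorded change at this position, a step that the limit leaves unreadable from compound 1 to compound 2, ran toward the limit. Compound 3 is expected at 200 nM, within 30 nM to 2000 nM, a step of a 12-fold higher number from compound 1 to compound 3 (1.09 log units; beyond the scatter) in this assay.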

Compound 3, half-maximal effective concentration: < 5020 nM
Compound 3 was reported as a limit; the forecaster's own chance of this, stated with the estimate: 15%; the middle value lies beyond the limit too.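

The steps from compound 1 to compound 3 and from compound 2 to compound 3 cannot be read, because compound 2 and compound 3 each give only a limit: the limit of < 5020 nM in this assay, at which 2 of the 3 values shown sit.

The compounds shown leave open the size and direction of replacing furan-2-yl at this aromatic carbon with either group.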